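The compounds below may be only part of what the source reports. "The series", "measured", "known", "first", "only" and "open" are said of these compounds alone.

The measured compounds, with their readings in a physicochemical assay for solubility, read by HPLC, with a stated time of 4 h, at pH 7; on this read-out higher numbers stand for higher solubility and lower numbers for lower solubility:

Compound 1 `C[C@]1(COc2ccc(N3CCN(S(=O)(=O)c4ccc(F)cc4)CC3)cc2)Cn2cc([N+](=O)[O-])nc2O1`: 8.33 ug/mL.
Compound 2 `CC(C)(C)c1ccc(NC(=O)Nc2ccc(OC[C@@]3(C)Cn4cc([N+](=O)[O-])nc4O3)cc2)cc1`: < 1 ug/mL, which is a limit of the assay.
Compound 3 `CCc1ccc(NC(=O)Nc2ccc(OC[C@@]3(C)Cn4cc([N+](=O)[O-])nc4O3)cc2)cc1`: < 1 ug/mL, which is a limit of the assay.

Compound 3 therefore stands at the floor of what this assay can report: its reading is a limit, not a number. For the measured compounds named here, compound 2 sits at the same limit, so the only one-place step between measured compounds, a step that the two limits leave unreadable from compound 2 to compound 3, cannot be read in either direction. Going by the values given here, compound 1 is the only member of the set with a numerical reading, and the limit of < 1 ug/mL in this assay, at which 2 of the 3 values shown sit, is where the other two readings sit.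

Compound 4 `Cc1ccc(NC(=O)Nc2ccc(OC[C@@]3(C)Cn4cc([N+](=O)[O-])nc4O3)cc2)cc1` differs from compound 3 by hydrogen in place of methyl on a saturated chain carbon bound to an aromatic carbon. Among the compounds with values here, no measured step bears directly on this change, and the one step that is available is unreadable, so there is nothing in the numbers that points to a move beyond the scatter. Compound 4 is expected to remain close to the same floor, with an estimate of 1.2 ug/mL, in a range from 0.4 ug/mL to 4 ug/mL, and the step of an at least 1.2-fold higher number from compound 3 to compound 4 (0.07 log units; that floor lies within the scatter) is expected to stay within the scatter, with a real chance that only a limit is reported again.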

Compound 4, solubility: < 1 ug/mL
Compound 4 was reported as a limit; the forecaster's own chance of this, stated with the estimate: 55%; middle value at least 1.2-fold (0.07 log units) away from the limit.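

Compound 4 reads as a limit at the floor of this assay, just as compound 2 and compound 3 do, so no step among these three compounds can be read, in size or in direction: the limit of < 1 ug/mL in this assay, at which 3 of the 4 values shown sit.

The compounds shown leave open how compound 2, compound 3 and compound 4 compare in solubility beneath that limit.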